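Swapping a cyclohexyl for a sulfone ring in a weak series

This account rests on a few compounds, and the source may have more. Where it says the series, first, only, none or still open, it means among the compounds named here.

Of the compounds shown here, two have been measured so far, and both sit at the edge of what the test can see. Compound 1, `c1ccc2c(c1)CN[C@@H](CN(CCCCN(Cc1ccncc1)Cc1ccncc1)[C@H]1CCCc3cccnc31)C2`, opens the set. In a functional assay on cells for agonist activity at C-X-C chemokine receptor type 4 (Homo sapiens), read by fluorescence and calcium flux, with a stated time of 90 s (on this read-out lower numbers stand for an effect already at smaller amounts and higher numbers for an effect only at larger amounts of compound), compound 1 gives > 30000 nM, which is a limit of the assay rather than a number. Compound 2, `c1ccc2c(c1)CN[C@@H](CN(CCCCNCC1CCCCC1)[C@H]1CCCc3cccnc31)C2`, carries a cyclohexylmethyl group in place of the larger arms of compound 1. In this assay compound 2 gives > 30000 nM, again a limit and not a measured number. Compound 2 therefore stands nowhere within the measurable range, and the summary of the two values is simply (the limit of > 30000 nM in this assay, at which 2 of the 2 values shown sit). Compound 3, `O=S1(=O)CCC(CNCCCCN(C[C@H]2Cc3ccccc3CN2)[C@H]2CCCc3cccnc32)CC1`, is the next variation: 1,1-dioxothian-4-yl in place of cyclohexyl on a saturated chain carbon bound to an amine nitrogen. Among the measured compounds shown here, with only two limits in hand, no measured step can guide the expectation. The step is expected to be a step that the limit leaves unreadable from compound 2 to compound 3, that is, nothing beyond the usual scatter. Compound 3 is estimated at 40000 nM, most likely between 8000 nM and 150000 nM.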

Compound 3, half-maximal effective concentration: > 30000 nM
Compound 3 was reported as a limit; the forecaster's own chance of this, stated with the estimate: 70%; the middle value does not contradict the limit.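

In this assay compound 3 gives > 30000 nM, a limit of the assay and not a number. Among the compounds shown here, compound 2 sits at a limit too, and no step between compound 2 and compound 3 can be read. The compounds shown leave open whether 1,1-dioxothian-4-yl in place of cyclohexyl changes the effect at all.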